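Replacing a ring-bearing amide substituent on the shared core

This account rests on a few compounds, and the source may have more. Where it says the series, first, only, none or still open, it means among the compounds named here.

Measured compounds:
Compound 1 `CCc1cnc(N2CCC(c3nc(COc4ccc(/C=C5\CC(=O)N(CC6CCOCC6)C5=O)cc4F)cs3)CC2)nc1`: 240 nM in a functional assay on cells for agonist activity at Glucose-dependent insulinotropic receptor (Homo sapiens), read by a luciferase reporter, with a stated time of 6 h; a higher number here means that more compound is needed for the effect, a lower number that less compound is needed
Compound 2 `NC(=O)CCc1cnc(N2CCC(c3nc(COc4ccc(-n5cnnn5)cc4)cs3)CC2)nc1`: "not determined" (no result reported) in this assay
Compound 3 `CCc1cnc(N2CCC(c3nc(COc4ccc(/C=C5\CCNC5=O)cc4F)cs3)CC2)nc1`: 100 nM in this assay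

Among the two compounds with a number in this assay, compound 1 stands highest: compound 3 shows the lower figure, and the gap between them lies beyond the usual scatter of this kind of measurement. Compound 2 was tested in no way that yielded a number, so nothing can be said of where it would fall.

Compound 4 `CCc1cnc(N2CCC(c3nc(COc4ccc(/C=C5\CC(=O)N(c6ccccc6)C5=O)cc4F)cs3)CC2)nc1` differs from compound 1 in one place: phenyl in place of (oxan-4-yl)methyl on an amide-type nitrogen in a ring. Among the measured compounds shown here, no pair of measured compounds differs in this same way, so there is no measured step to lean on. The author expects the step from compound 1 to compound 4 to be small, with no direction that would reach beyond the scatter, and so the value of compound 4 in this assay is estimated at 250 nM, within the range 100 nM to 600 nM, which corresponds to an expected step of a 1.0-fold higher number from compound 1 to compound 4 (0.02 log units; within the scatter).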

Compound 4, half-maximal effective concentration: 82 nM
Estimate against measurement, compound 4: 3.0-fold (0.48 log units) above, and the stated range ends above it.
By their numbers in this assay, from the lowest: compounds 4 and 3 (each within the scatter of the next); then compound 1.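

In this assay, phenyl in place of (oxan-4-yl)methyl on the amide-type nitrogen in a ring gives a 2.9-fold lower number from compound 1 to compound 4 (0.47 log units; beyond the scatter), a modest step but one beyond the scatter. Among the compounds shown here, this is the first sign that the group at this position affects the result, as no earlier pair of compounds differed here. It also shows that this position does not need the non-aromatic ring with its oxygen, since an aromatic ring of carbon only serves at least as well. No measurement shown accounts for the change.

Going by these compounds, what remains open is whether the aromatic ring or the absence of the carbon link drives the step, which a benzyl group would help to separate. On these data alone, it is also open how a pyridyl ring, or a phenyl ring carrying an amine or a carboxylic acid, would behave at this position.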